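A Sulfonyl for a Benzyl on the Ring Nitrogen

The source may hold more compounds than are shown below. What is called first, only, known or untested is meant among the compounds shown, and "the series" means these compounds.

Of the compounds shown here, three built on one shared core have been tested in an assay on HEK293 cells for displacement of a labelled ligand from 5-hydroxytryptamine receptor 6 (Homo sapiens), read by scintillation counting, with a stated time of 1 h; on this read-out lower numbers stand for stronger inhibition and higher numbers for weaker inhibition. Compound 1 `C[C@H](NCc1ccc(OCCCCN2CCN(c3cccc4c3ccn4Cc3cccc(Cl)c3)CC2)cc1)C(N)=O` gives 162 nM. Compound 2 `C[C@H](NCc1ccc(OCCCCN2CCN(c3cccc4c3ccn4S(=O)(=O)c3ccccc3)CC2)cc1)C(N)=O` gives 68 nM. Compound 3 `C#CCN(C)Cc1ccc(OCCCCN2CCN(c3cccc4c3ccn4Cc3cccc(Cl)c3)CC2)cc1` gives 195 nM, the highest of the three numbers; the gap here is only a 1.2-fold higher number from compound 1 to compound 3 (0.08 log units; within the scatter), whereas compound 2 sits clearly further away with a lower number.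

Compound 4 `C#CCN(C)Cc1ccc(OCCCCN2CCN(c3cccc4c3ccn4S(=O)(=O)c3ccccc3)CC2)cc1` has not yet been measured. It differs from compound 3 in a single place: phenylsulfonyl in place of 3-chlorobenzyl on an aromatic nitrogen. This very exchange has been seen once already, going from compound 1 to compound 2, where it produced a 2.4-fold lower number from compound 1 to compound 2 (0.38 log units; beyond the scatter), a modest but real shift toward stronger binding. The other end of the molecule, where compound 1 and compound 3 differ, has left the numbers almost unchanged (a 1.2-fold higher number from compound 1 to compound 3 (0.08 log units; within the scatter)), so that part is not expected to alter how the exchange behaves. A step of about a 2.4-fold lower number from compound 3 to compound 4 (0.39 log units; beyond the scatter) is therefore expected for compound 4 in this assay, in the direction of a lower number. Compound 4 is estimated to come out near 80 nM, with a likely range from 35 nM to 180 nM.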

Compound 4, inhibition constant: 54 nM
Compound 4: the middle estimate sits 1.5-fold (0.17 log units) above what was measured; measured number inside the range.
By their numbers in this assay, from the lowest: compounds 4 and 2 (each within the scatter of the next); then compounds 1 and 3 (each within the scatter of the next).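

On the aromatic nitrogen, the exchange of 3-chlorobenzyl for phenylsulfonyl has now been read on a second core, where this assay shows a 3.6-fold lower number from compound 3 to compound 4 (0.56 log units; beyond the scatter), so the earlier shift was not confined to compound 2 and its partner, and the two steps agree in size as well as direction: the same change on two cores in this assay, a 2.4-fold lower number (0.38 log units; beyond the scatter) from compound 1 to compound 2 and a 3.6-fold lower number (0.56 log units; beyond the scatter) from compound 3 to compound 4, 1.5-fold (0.18 log units) apart, within the scatter of two such steps. The change at the other end of the molecule, methyl(propargyl)amino in place of (1-carbamoylethyl)amino, can now also be read with phenylsulfonyl in place, where it gives a 1.3-fold lower number from compound 2 to compound 4 (0.10 log units; within the scatter), and it again makes no difference beyond the scatter: the same change on two cores in this assay, a 1.2-fold higher number (0.08 log units; within the scatter) from compound 1 to compound 3 and a 1.3-fold lower number (0.10 log units; within the scatter) from compound 2 to compound 4, 1.5-fold (0.18 log units) apart, within the scatter of two such steps. For the compounds shown here, in these four compounds, the two ends therefore behave as separate parts, with the phenylsulfonyl step holding for both amines and no compound going against this.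

Since phenylsulfonyl brings a sulfonyl group and also loses the chlorine, the compounds shown cannot say which part of the exchange matters, and an unsubstituted benzyl or a methylsulfonyl group on the same nitrogen would help separate the two. They also leave open whether the insensitivity at the other end would extend to a carboxylic acid there.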